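A few compounds are considered here, and "the series" means these few. Any claim that something is new, unique, unknown or untested is made for them only; others in the source may bear on it.

Compound 1 `CC1=C(C(=O)Nc2ccc(F)c(Cl)c2)C(c2cccc(Oc3ccccc3)c2)NC(=S)N1` has been tested in a functional assay on NCI/ADR-RES cells (Homo sapiens) for cytotoxicity, read by sulforhodamine B assay, with a stated time of 48 h (on this read-out higher numbers stand for weaker inhibition of growth and lower numbers for stronger inhibition of growth), where compound 1 gives 15500 nM. Compound 2 `CC1=C(C(=O)Nc2ccc(F)c(Cl)c2)C(c2cccc(O)c2)NC(=S)N1` differs from it only at the oxygen on the aromatic ring, and in this assay compound 2 gives 17000 nM. The step of a 1.1-fold higher number from compound 1 to compound 2 (0.04 log units; within the scatter) shows that replacing the phenyl on that oxygen with a hydrogen left the read-out where it was. Among the compounds with values here, with only two numbers known, compound 2 and compound 1 lie within the scatter of each other, so neither can be called the more active.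

Compound 3 `COc1cccc(C2NC(=S)NC(C)=C2C(=O)Nc2ccc(F)c(Cl)c2)c1` has not yet been measured. It differs from compound 2 by methyl in place of hydrogen on an oxygen on an aromatic ring. Within the data shown here, the one measured step that touches this same oxygen is the one from compound 1 to compound 2, and it stayed within the scatter, so both a phenyl and a hydrogen on that oxygen gave the same result. On that basis, the step of a 1.1-fold lower number from compound 2 to compound 3 (0.03 log units; within the scatter) is expected to be no larger than the scatter. In this assay, compound 3 is therefore estimated at 16000 nM, with a range from 7000 nM to 36000 nM.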

Compound 3, concentration for 50% growth inhibition: 15500 nM
For compound 3 the middle estimate is 1.0-fold (0.01 log units) above the measured one; measured number inside the range.
By their numbers in this assay, from the lowest: compounds 1, 3 and 2 (each within the scatter of the next).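

Compound 3 adds a third group on the oxygen on the aromatic ring, a methyl, to the phenyl and hydrogen already seen there. In this assay the step from the hydroxy to the methoxy form gives a 1.1-fold lower number from compound 2 to compound 3 (0.04 log units; within the scatter) and the exchange of phenyl for methyl gives no change at the digits printed from compound 1 to compound 3 (within the scatter) so all three compounds now lie within the scatter of one another. The earlier pair could only show that two very different groups on this oxygen gave matching read-outs, whereas this series shows the same for a group of intermediate size, with one heavy atom, and across these three compounds the read-out does not follow the size of the group; nothing available explains this result.

As far as these compounds go, what a longer chain such as propyl on the oxygen would do remains open, as does the effect of replacing the hydroxy group with an amine or a carboxylic acid. All three compounds share the rest of their structure, so these numbers also leave open whether changes elsewhere in the shared core would move the read-out beyond the scatter.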